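The source may hold more compounds than are shown below. What is called first, only, known or untested is meant among the compounds shown, and "the series" means these compounds.

In a functional assay on K562 cells (Homo sapiens) for antiproliferative activity, read by fluorescence, with a stated time of 3 days (on this read-out lower numbers stand for stronger inhibition and higher numbers for weaker inhibition), compound 1 `CCCCCSc1nc(OC(=O)CC(C)(C)C)c2cn[nH]c2n1` gives 19800 nM. Compound 2 `Clc1ccccc1Nc1nc(SCCc2ccccc2)nc2[nH]ncc12` gives 19900 nM and compound 3 `O=[N+]([O-])c1cccc(Nc2nc(SCCc3ccccc3)nc3[nH]ncc23)c1` gives 19900 nM. These three numbers lie within the scatter of one another, so compound 1 stands level with the other two, and no ranking can be drawn among them.

Compound 4 `CCCCCSc1nc(OC(=O)c2ccco2)c2cn[nH]c2n1` departs from compound 1 at a single place: furan-2-yl in place of neopentyl on a carbonyl carbon. In short, furan-2-yl stands in place of neopentyl on a carbonyl carbon.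

Among the compounds with values here, only one measured step links two compounds that differ in one place, and it reads no change at the digits printed from compound 2 to compound 3 (within the scatter). That step concerns a different place, 3-nitrophenyl in place of 2-chlorophenyl on a nitrogen on an aromatic ring, so it bears on this change only indirectly. No measured compound carries furan-2-yl, and nothing shown points in either direction. No step beyond the scatter is therefore expected, although the range must stay wide. The estimated change is a 1.1-fold lower number from compound 1 to compound 4 (0.04 log units; within the scatter). For compound 4 the expected value is 18000 nM, with an estimated range of 8000 nM to 35000 nM.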

Compound 4, half-maximal inhibitory concentration: 19800 nM
Estimate against measurement, compound 4: 1.1-fold (0.04 log units) below, and the stated range covers the measured number.
By their numbers in this assay, from the lowest: compounds 1, 4, 2 and 3 (each within the scatter of the next).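

At this place, on a carbonyl carbon whose other neighbour is an oxygen next to a carbonyl group, furan-2-yl replaces neopentyl with no change at the digits printed from compound 1 to compound 4 (within the scatter) in this assay. Within the data shown here, the earlier step concerned a different place, a nitrogen on an aromatic ring, so this is the first reading of the carbonyl side of the molecule. The swap keeps the count of heavy atoms but brings in a five-membered aromatic ring and a hydrogen-bond acceptor, and this read-out does not register the exchange.

As far as these compounds go, whether an amine, a carboxylic acid or a longer chain at this carbonyl carbon would shift the number remains open. No evidence is available here that could explain why these two groups read alike.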